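The compounds below may be only part of what the source reports. "The series", "measured", "known", "first", "only" and "open" are said of these compounds alone.

Compounds measured so far:
compound 1, `COc1ncc(-c2ccc3nccc(N4CCCC4)c3c2)cc1NS(=O)(=O)c1ccc(F)cc1F`, 3410 nM
compound 2, `COc1ncc(-c2ccc3nccc(-c4ccc(C)cc4)c3c2)cc1NS(=O)(=O)c1ccc(F)cc1F`, 1240 nM
compound 3, `CNCCN(C)Cc1ccc(-c2ccnc3ccc(-c4cnc(OC)c(NS(=O)(=O)c5ccc(F)cc5F)c4)cc23)cc1`, 13 nM

In a functional assay on A549 cells (Homo sapiens) for cytotoxicity, read by MTT assay, with a stated time of 72 h (a lower number here means a stronger inhibitor, a higher number a weaker inhibitor), compound 3 gives the lowest number of the three; the nearest is compound 2, and the furthest compound 1. Compound 4, `COc1ncc(-c2ccc3nccc(-c4ccc(CN5CCCCC5)cc4)c3c2)cc1NS(=O)(=O)c1ccc(F)cc1F`, differs from compound 3 by piperidin-1-yl in place of methyl(2-(methylamino)ethyl)amino on a saturated chain carbon bound to an aromatic carbon. The step that bears on this change is a 95-fold lower number from compound 2 to compound 3 (1.98 log units; beyond the scatter), which attached the group now leaving; the other step, a 2.8-fold lower number from compound 1 to compound 2 (0.44 log units; beyond the scatter), lies elsewhere. Since compound 4 keeps a nitrogen-bearing chain at this position but not the same one, the number for compound 4 is expected to sit between those of compound 2 and compound 3, a step of a 12-fold higher number from compound 3 to compound 4 (1.06 log units; beyond the scatter), with an estimate of 150 nM within 30 nM to 800 nM.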

Compound 4, half-maximal inhibitory concentration: 15.5 nM
Compound 4: the middle estimate sits 9.7-fold (0.99 log units) above what was measured; measured number below the stated range.
By their numbers in this assay, from the lowest: compounds 3 and 4 (each within the scatter of the next); then compound 2; then compound 1.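

In this assay, piperidin-1-yl replaces methyl(2-(methylamino)ethyl)amino on the saturated chain carbon with a step within the scatter, a 1.2-fold higher number from compound 3 to compound 4 (0.08 log units; within the scatter), so an open chain with a hydrogen-bond donor is not required there for a low number. Set against hydrogen at that carbon, the ring amine alone gives a large step, an 80-fold lower number from compound 2 to compound 4 (1.90 log units; beyond the scatter). No measurement given here explains this.

Whether the amine nitrogen itself is needed remains open, as the compounds shown do not include a cyclohexyl group at this carbon. On these data alone, how a morpholine ring or a carboxylic acid would fare there also remains unknown.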